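Swapping the pyridine in compound 1 for a methylated pyridine

The source may hold more compounds than are shown below. What is called first, only, known or untested is meant among the compounds shown, and "the series" means these compounds.

Measured compounds:
compound 1, `O=C(c1ccccc1)N1CCn2nc(-c3ccncc3)cc2C1`, gives 1290 nM in a functional assay on HEK293 cells for negative allosteric modulation of metabotropic glutamate receptor 5 (Homo sapiens), read by calcium flux, with a stated time of 20 min; a higher number here means a weaker inhibitor, a lower number a stronger inhibitor
compound 2, `O=C(c1ccc(Cl)cc1)N1CCn2nc(-c3ccccn3)cc2C1`, gives 9470 nM in this assay

Going by the values given here, of the two numbers known, compound 1 has the lower, and its gap to compound 2 is beyond the scatter of repeated measurements. Compound 3, `Cc1cccc(-c2cc3n(n2)CCN(C(=O)c2ccccc2)C3)n1`, has not been measured. It differs from compound 1 in one place: 6-methylpyridin-2-yl in place of pyridin-4-yl on an aromatic carbon. Among the compounds with values here, no single-change pair among the measured compounds shows what such a swap does; compound 2 carries a different pyridine and also a chloro group on the benzoyl ring, so its weaker number cannot be traced to either change alone. The expectation for the step of a 1.6-fold higher number from compound 1 to compound 3 (0.19 log units; within the scatter) is therefore a small one, within or just beyond the scatter, with a slight lean toward a weaker inhibitor. Compound 3 is thus estimated at 2000 nM, with a range from 500 nM to 8000 nM.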

Compound 3, half-maximal inhibitory concentration: 568 nM
For compound 3 the middle estimate is 3.5-fold (0.55 log units) above the measured one; the range from low to high includes it.
By their numbers in this assay, from the lowest: compound 3; then compound 1; then compound 2.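

Swapping pyridin-4-yl for 6-methylpyridin-2-yl gives a 2.3-fold lower number from compound 1 to compound 3 (0.36 log units; beyond the scatter) in this assay and is the only single-place step available so far, so it offers the first direct reading of this position on the five-membered aromatic ring. Compound 3 shows that pyridin-4-yl is not required at this position for inhibition on the core of compound 1, and that this replacement gives a modest gain rather than a loss. Nothing measured alongside these compounds explains the step.

The swap alters both where the ring nitrogen sits and whether a methyl is present, and compound 2 cannot separate the two, as it also carries a chloro group on the benzoyl ring. From the compounds shown here alone, it also remains open how an ethyl or methoxy group in place of that methyl, or a plain phenyl ring in place of the pyridine, would fare.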